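The compounds below may be only part of what the source reports. "The series", "measured", "known", "first", "only" and "open" are said of these compounds alone.

In a functional assay on A498 cells (Homo sapiens) for cytotoxicity, read by sulforhodamine B assay, with a stated time of 48 h (on this read-out lower numbers stand for stronger inhibition of growth and higher numbers for weaker inhibition of growth), compound 1 (`COc1cc(C(=O)c2ccc(OC)c(O)c2OC)cc(OC)c1O`) gives 1700 nM and lies within the scatter of compound 2 (`COc1cc(C(=O)c2ccc3c(c2)oc(=O)n3S(C)(=O)=O)cc(OC)c1OC`) at 3110 nM in the same read-out. Among the compounds with values here, these two values are the only measurements so far, and they give no ranking of the pair. Compound 3 (`COc1ccc(C(=O)c2cc(OC)c(OC)c(OC)c2)c(OC)c1O`) differs from compound 1 by methyl in place of hydrogen on an oxygen on an aromatic ring and nothing else, a change of hydroxy to methoxy. Within the data shown here, no measured pair gives the size of such a step in this assay so the expectation is a tentative one: a modest move toward stronger growth inhibition, little beyond the scatter. The expected step is a 2.1-fold lower number from compound 1 to compound 3 (0.33 log units; beyond the scatter) and it carries a wide margin in both directions. For compound 3 the estimated value is 800 nM with an expected range from 150 nM to 3500 nM until a measurement is available.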

Compound 3, concentration for 50% growth inhibition: 2720 nM
The estimate for compound 3 lay 3.4-fold (0.53 log units) below the measured number; measured number inside the range.
By their numbers in this assay, from the lowest: compounds 1, 3 and 2 (each within the scatter of the next).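

In this assay, within the data shown here, methyl in place of hydrogen on an oxygen on an aromatic ring gives a 1.6-fold higher number from compound 1 to compound 3 (0.20 log units; within the scatter), the first measured step for this change. At this position, the hydrogen of the hydroxy is therefore not shown to matter for the read-out: hydroxy to methoxy leaves the two compounds indistinguishable, although the second hydroxy of compound 1 remains in compound 3. No supporting data bear on why this step is so small.

Open, on these data alone, is whether an ethyl or a longer chain on this oxygen, or an amine in place of the hydroxy, would give a step beyond the scatter. Also open is what the remaining hydroxy contributes, since replacing it with methoxy or with fluorine is not covered by the compounds shown here.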